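Swapping a Pyridine for a Tetrahydroisoquinoline: Solubility Outlook

This account rests on a few compounds, and the source may have more. Where it says the series, first, only, none or still open, it means among the compounds named here.

Compound 2 `COc1ccc2[nH]c(C(=O)N3CC(=O)N(Cc4ccccc4)[C@@H](Cc4ccccn4)C3)cc2c1` has been tested in a physicochemical assay for solubility, read by spectrophotometry, in phosphate buffer, with a stated time of 2 h, at pH 7.4; a higher number here means a more soluble compound, a lower number a less soluble compound. In this assay compound 2 gives > 100000 nM, which is a limit of the measurement rather than an exact number. Within the data shown here, compound 1 `COc1cccc(CN2C(=O)CN(C(=O)c3cc4cc(OC)ccc4[nH]3)C[C@@H]2Cc2ccccn2)c1` gives 57900 nM; the only measured step, an at least 1.7-fold higher number from compound 1 to compound 2 (0.23 log units; that floor lies within the scatter), lies within the scatter and concerns hydrogen in place of methoxy on an aromatic carbon. Compound 4 `COc1ccc2[nH]c(C(=O)N3CC(=O)N(Cc4ccccc4)[C@@H](CN4CCc5ccccc5C4)C3)cc2c1` differs from compound 2 elsewhere: 1,2,3,4-tetrahydroisoquinolin-2-yl in place of pyridin-2-yl on a saturated chain carbon bound to a saturated ring carbon. Among the measured compounds shown here, no measured step touches this saturated chain carbon. Compound 3 `COc1ccc2[nH]c(C(=O)N3CC(=O)N(Cc4ccccc4)[C@@H](CN4CCN(c5ccc(F)cc5)CC4)C3)cc2c1`, which carries a different group on that saturated chain carbon, gives 20700 nM. A lower number is therefore expected for compound 4, with wide uncertainty. Compound 4 is estimated at 30000 nM, between 8000 nM and 100000 nM, an expected step of an at least 3.3-fold lower number from compound 2 to compound 4 (0.52 log units; beyond the scatter).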

Compound 4, solubility: 9000 nM
Beside the measured number, compound 4's estimate is 3.3-fold (0.52 log units) above it, and the stated range covers the measured number.
By their numbers in this assay, from the lowest: compound 4; then compound 3; then compound 1. At a limit, above all of these: compound 2.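

Swapping pyridin-2-yl for 1,2,3,4-tetrahydroisoquinolin-2-yl gives the first measured step at this saturated chain carbon: in this assay there is an at least 11-fold lower number from compound 2 to compound 4 (1.04 log units; beyond the scatter). Among these compounds, the one earlier step, on an aromatic carbon, stayed within the scatter, whereas this one lies beyond it. The step is only a floor, since the value for compound 2 is a limit: the limit of > 100000 nM in this assay, at which 1 of the 4 values shown sits.

The compounds shown leave open whether the non-aromatic ring alone, as in a piperidine, would give a similar number, or whether the fused benzene ring is also needed. On these data alone, how a morpholine at this carbon would read also remains open.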